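A few compounds are considered here, and "the series" means these few. Any claim that something is new, unique, unknown or untested is made for them only; others in the source may bear on it.

Measured compounds:
- compound 1, `CCNC(=O)NCC1CCc2c(OC)cccc2N1C`: 160 nM
- compound 2, `CCNC(=O)NCC1CCc2c(cccc2OC)N1`: "not determined" (no result reported)
- compound 3, `CCC(=O)NCC1CCc2ccc(OC)cc2N1Cc1ccccc1`: "not determined" (no result reported)

In a functional assay on CHO cells with melatonin receptor type 1A (Homo sapiens) as the target, read by GTPgammaS binding, with a stated time of 1 h (a higher number here means that more compound is needed for the effect, a lower number that less compound is needed), compound 1 gives 160 nM. Within the data shown here, compound 2 has no result in this assay, and compound 3 has none either, so there is no number from which to start the step to compound 4, and no measured pair of neighbouring compounds shows how large a change of this kind usually is.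

Compound 4, `CCC(=O)NCC1CCc2ccccc2N1Cc1ccccc1`, differs from compound 3 in one place: hydrogen in place of methoxy on an aromatic carbon. The methoxy group is thus removed and nothing takes its place beyond a hydrogen atom. Among the measured compounds shown here, the only number in the set belongs to compound 1, which keeps its methoxy group and gives 160 nM in this assay; compound 4 lacks that group and shares no other measured neighbour.

Without a value for compound 3 no direction or size of step can be drawn from the numbers. For compound 4 the expected value in this assay is 3000 nM, with a range from 300 nM to 30000 nM, and a result given only as a limit would not be surprising.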

Compound 4, half-maximal effective concentration: 36 nM
Estimate against measurement, compound 4: 83-fold (1.92 log units) above; measured number below the stated range.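

In this assay, among these compounds, compound 4 gives 36 nM but compound 3 has no single number there, so no step between these two compounds can be read. From the compounds shown here alone, what taking away the methoxy group does to this value stays open. Nothing further on hand bears on this result.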